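A few compounds are considered here, and "the series" means these few. Any claim that something is new, unique, unknown or untested is made for them only; others in the source may bear on it.

Measured so far in a functional assay on A-431 cells (Homo sapiens) for antiproliferative activity, read by MTT assay, with a stated time of 72 h; on this read-out higher numbers stand for weaker inhibition and lower numbers for stronger inhibition:
compound 1 `NS(=O)(=O)c1ccc(NC(=S)Nc2ccc3ncnc(Nc4ccc(F)c(Cl)c4)c3c2)cc1` — 37600 nM
compound 2 `NS(=O)(=O)c1ccc(NC(=S)Nc2ccc3ncnc(Nc4cccc(Br)c4)c3c2)cc1` — 20700 nM
compound 3 `NS(=O)(=O)c1ccc(NC(=S)Nc2ccc3ncnc(Nc4ccc(C(F)(F)F)cc4)c3c2)cc1` — 18000 nM

Compound 3 gives the lowest of the three numbers, but its gap to compound 2 is within the scatter, a 1.2-fold lower number from compound 2 to compound 3 (0.06 log units; within the scatter), and only its gap to compound 1 is beyond it, a 2.1-fold lower number from compound 1 to compound 3 (0.32 log units; beyond the scatter). On these numbers compound 3 and compound 2 cannot be told apart; the whole set sits in a narrow band.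

Compound 4 `Cc1cccc(Nc2ncnc3ccc(NC(=S)Nc4ccc(S(N)(=O)=O)cc4)cc23)c1` has not yet been measured in this assay. It differs from compound 3 as follows: 3-methylphenyl in place of 4-(trifluoromethyl)phenyl on a nitrogen on an aromatic ring. The same site has been varied in every measured step: a 1.8-fold lower number from compound 1 to compound 2 (0.26 log units; within the scatter), a 2.1-fold lower number from compound 1 to compound 3 (0.32 log units; beyond the scatter) and a 1.2-fold lower number from compound 2 to compound 3 (0.06 log units; within the scatter). All three are small, and two of them lie within the scatter. Nothing in the measured steps picks out any aryl group at this site as moving the number far in either direction, so for compound 4 a step of about the scatter or less is expected, leaning if anything toward a somewhat higher number because compound 3 already stands at 18000 nM, the lowest point of the band. The expected step is a 1.1-fold higher number from compound 3 to compound 4 (0.05 log units; within the scatter). Compound 4 is estimated at 20000 nM, with a range from 8000 nM to 50000 nM.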

Compound 4, half-maximal inhibitory concentration: 23800 nM
Beside the measured number, compound 4's estimate is 1.2-fold (0.08 log units) below it; low and high end bracket the measured number.
By their numbers in this assay, from the lowest: compounds 3, 2, 4 and 1 (each within the scatter of the next, the first and the last beyond it).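

In this assay, the all-carbon 3-methylphenyl stays in the same narrow band as the halogen-bearing and trifluoromethyl-bearing aryl groups, against 4-(trifluoromethyl)phenyl (a 1.3-fold higher number from compound 3 to compound 4 (0.12 log units; within the scatter)) and against 3-chloro-4-fluorophenyl (a 1.6-fold lower number from compound 1 to compound 4 (0.20 log units; within the scatter)). The closest comparison is methyl in place of bromo on an aromatic carbon (a 1.1-fold higher number from compound 2 to compound 4 (0.06 log units; within the scatter)), a single-group exchange that leaves the number within the scatter. Among these four compounds, then, fluorine, chlorine or bromine on the aryl group is not required for a value in this band, and the one gap beyond the scatter remains that between compound 1 and compound 3. No supporting data bear on why these aryl groups give such similar values.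

Going by these compounds, all four compounds carry a lipophilic-neutral-free description only as aryl groups with no hydrogen-bond donors or acceptors counted on them, so an amine, a carboxylic acid or a hydroxyl on this aryl ring remains untested here. On these data alone, whether any such group, or a longer chain in place of the aryl group on the nitrogen, would move the number out of this band stays open.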